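The source may hold more compounds than are shown below. What is called first, only, known or untested is meant among the compounds shown, and "the series" means these compounds.

Measured compounds:
- compound 1, `CC(=O)c1cccc(Nc2ccnc(SCC(=O)c3ccc(C(F)(F)F)cc3)n2)c1`: 22%
- compound 2, `CCOC(=O)c1ccc(Nc2ccnc(SCC(=O)c3ccc([N+](=O)[O-])cc3)n2)cc1`: 22%

Both compounds were examined in a functional assay on MDA-MB-231 cells (Homo sapiens) for inhibition, read by sulforhodamine B assay, with a stated time of 48 h, tested at 10 uM; a lower number here means less inhibition of growth, a higher number more inhibition of growth at the concentration tested. In this assay compound 1 gives 22%, and compound 2 gives 22%. Compound 2 thus stands level with compound 1 at the digits shown; the two readings lie within the usual scatter of each other, so no ordering between them can be claimed. Among the measured compounds shown here, the two compounds differ in more than one place, so no single structural step connects them, and their values show only that neither stands apart from the other.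

The next compound, compound 3, `CCOC(=O)c1ccc(Nc2ccnc(SCC(=O)c3ccc(C#N)cc3)n2)cc1`, is reached from compound 2 by a single change: cyano in place of nitro on an aromatic carbon. For the measured compounds named here, no measured pair in this set shows what such an exchange does in this assay, so the expectation rests on the two readings alone. From compound 2 to compound 3 the step is expected to be small, no change at the digits printed from compound 2 to compound 3 (within the scatter), with no clear direction beyond the scatter. Compound 3 is accordingly estimated at 22%, within a range from 8% to 40%.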

Compound 3, percent growth inhibition at one concentration: 19%
Compound 3: middle estimate off by 3 percentage points, on the high side, within the range that was stated.
By their numbers in this assay, from the lowest: compounds 3, 1 and 2 (each within the scatter of the next).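

Among the compounds shown here, compound 2 and compound 3 form the first pair in this set that differs in one place only, so a single change can be read directly for the first time: in this assay, cyano in place of nitro gives a number 3 percentage points lower from compound 2 to compound 3 (within the scatter). At this place, on an aromatic carbon para to a large group, the 4-nitrophenyl and the 4-cyanophenyl compound therefore cannot be told apart, even though a group of three heavy atoms, two of them oxygen, gives way to a group of two with a triple bond. For the compounds shown here, no measurement is at hand that would explain this reading, and it describes only this one pair at this one test concentration.

From the compounds shown here alone, what an amine or a carboxylic acid at this same place would give remains open, and so does whether the exchange would read the same way in a compound with another group in place of the ethyl ester. Both compounds of the pair also sit low on this scale, so a longer chain or other change elsewhere on the shared core could still behave quite differently.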